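From Compound 3 to Compound 4: Chloro Gives Way to Methyl

This account rests on a few compounds, and the source may have more. Where it says the series, first, only, none or still open, it means among the compounds named here.

Compound 1 `CCC(C)c1cc(C)c(C(=O)N=C(N)N)cc1S(C)(=O)=O`: 8 nM
Compound 2 `CCOc1cc(C)c(C(=O)N=C(N)N)cc1S(C)(=O)=O`: 19 nM
Compound 3 `CS(=O)(=O)c1cc(C(=O)N=C(N)N)c(Cl)cc1Oc1cccnc1`: 52 nM

In a functional assay for inhibition of sodium/hydrogen exchanger (Oryctolagus cuniculus) (on this read-out lower numbers stand for stronger inhibition and higher numbers for weaker inhibition), compound 3 gives the highest of the three numbers; compound 2 sits nearest to it and compound 1 furthest. Compound 4 `Cc1cc(Oc2cccnc2)c(S(C)(=O)=O)cc1C(=O)N=C(N)N` differs from compound 3 in one place: methyl in place of chloro on an aromatic carbon. Among the compounds with values here, the only measured step, a 2.4-fold higher number from compound 1 to compound 2 (0.38 log units; beyond the scatter), concerns a different group at a different position, so it offers little guidance for a chloro-to-methyl exchange. Within the data shown here, with no directly comparable step, the expected step of a 1.0-fold lower number from compound 3 to compound 4 (0.02 log units; within the scatter) is estimated to stay within the scatter. Compound 4 is therefore expected to give about 50 nM, in a range from 20 nM to 130 nM.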

Compound 4, half-maximal inhibitory concentration: 8.8 nM
Estimate against measurement, compound 4: 5.7-fold (0.75 log units) above, and the stated range ends above it.
By their numbers in this assay, from the lowest: compounds 1 and 4 (each within the scatter of the next); then compound 2; then compound 3.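

In this assay the exchange of chloro for methyl, para to a methylsulfonyl group, gives a 5.9-fold lower number from compound 3 to compound 4 (0.77 log units; beyond the scatter) and shows that this position responds to a change of a single heavy atom. With methyl in place, pyridin-3-yl in place of ethyl on the oxygen gives a 2.2-fold lower number from compound 2 to compound 4 (0.33 log units; beyond the scatter) while (pyridin-3-yl)oxy in place of sec-butyl gives a 1.1-fold higher number from compound 1 to compound 4 (0.04 log units; within the scatter) and leaves those two groups within the scatter of each other. Going by these compounds, how a bromo group or an amine would read at this position remains open. Nothing available accounts for the chloro-to-methyl step.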